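The compounds below may be only part of what the source reports. "The series", "measured", "known", "first", "only" and "open" are said of these compounds alone.

Measured compounds in an assay on membranes from Cortex for displacement of a labelled ligand from Sigma non-opioid intracellular receptor 1 (Cavia porcellus), read by scintillation counting, with a stated time of 120 min; a lower number here means a stronger inhibitor, a higher number a weaker inhibitor:
- compound 1 `OC(Cc1ccccc1)CN1CCC(NCCSC(c2ccc(F)cc2)c2ccc(F)cc2)CC1`: 309 nM
- compound 2 `Fc1ccc(C(SCCNC2CCN(Cc3cc4ccccc4[nH]3)CC2)c2ccc(F)cc2)cc1`: 205 nM
- compound 3 `CC(C)(C)C(=O)N1CCC(NCCSC(c2ccc(F)cc2)c2ccc(F)cc2)CC1`: 163 nM

Compound 3 stands at 163 nM in this assay; the steps of a 1.9-fold lower number from compound 1 to compound 3 (0.28 log units; within the scatter) and a 1.3-fold lower number from compound 2 to compound 3 (0.10 log units; within the scatter) are both within the scatter, as is a 1.5-fold lower number from compound 1 to compound 2 (0.18 log units; within the scatter), so the three compounds cannot be separated on these numbers.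

Compound 4 `Fc1ccc(C(SCCNC2CCN(CC3CC3)CC2)c2ccc(F)cc2)cc1` carries the change (cyclopropylmethyl in place of (tert-butyl)carbonyl on an amine nitrogen in a ring). The three measured steps all exchange the group on the same ring nitrogen, and none of them moved the number beyond the scatter. The same is therefore expected here: the estimated step is a 1.0-fold higher number from compound 3 to compound 4 (0.02 log units; within the scatter), within the scatter, in no reliable direction.

Compound 4 is expected near 170 nM in this assay, with an estimated range of 60 nM to 450 nM.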

Compound 4, inhibition constant: 269 nM
For compound 4 the middle estimate is 1.6-fold (0.20 log units) below the measured one, and the stated range covers the measured number.
By their numbers in this assay, from the lowest: compounds 3, 2, 4 and 1 (each within the scatter of the next).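

In this assay, the ring amine nitrogen now also accepts cyclopropylmethyl, a group with a three-membered ring and no carbonyl, and each step to compound 4 stays within the scatter (a 1.7-fold higher number from compound 3 to compound 4 (0.22 log units; within the scatter)) (a 1.3-fold higher number from compound 2 to compound 4 (0.12 log units; within the scatter)) (a 1.1-fold lower number from compound 1 to compound 4 (0.06 log units; within the scatter)). Giving up the carbonyl and its hydrogen-bond acceptor therefore produces no separable change at this nitrogen, and all four groups remain indistinguishable on these numbers. No supporting measurement bears on this result.

On these data alone, whether any group on this nitrogen can move the number beyond the scatter remains open. A carboxylic acid or a longer chain ending in an amine there would test this.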